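The compounds below may be only part of what the source reports. "The series", "measured", "known", "first", "only" and "open" are said of these compounds alone.

Of the compounds shown here, three with a shared core have been measured in an assay on CHO cells for displacement of a labelled ligand from adenosine receptor A1 (Homo sapiens), read by scintillation counting, with a stated time of 120 min, tested at 1 uM; a higher number here means more inhibition at the concentration tested (going by the name of the read-out), a lower number less inhibition. Compound 1, with the structure `COc1ccc(C(=O)Nc2nc(-c3ccc(OC)cc3)nc3cn(-c4ccccc4)nc23)cc1`, is the starting point of the comparison. In this assay compound 1 gives 3%, the lowest of the three numbers. Compound 2, with the structure `Cn1cc2nc(-c3ccccc3)nc(N)c2n1`, gives 31% in this assay, a reading well beyond the usual scatter above that of compound 1. Compound 3, with the structure `Nc1nc(-c2ccccc2)nc2nn(-c3ccccc3)nc12`, gives 38% in this assay and stands furthest from compound 1. Among the measured compounds shown here, compounds 2 and 3 both carry a free amino group where compound 1 carries an amide, and both read higher, but with only three compounds no firm pattern can be claimed.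

The unmeasured compound 4, with the structure `COc1ccc(-c2nc(NC(=O)c3ccncc3)c3nn(-c4ccccc4)cc3n2)cc1`, is obtained from compound 1 by a single change: pyridin-4-yl in place of 4-methoxyphenyl on a carbonyl carbon. The rest of the molecule, including the amide link and the shared core, is untouched. For the measured compounds named here, no pair of measured compounds shows this kind of swap, so its effect is unknown here; the amide-bearing compound 1 sits near the bottom of the scale, which leaves little room for a fall. The step from compound 1 to compound 4 is expected to be small, in the order of a number 5 percentage points higher from compound 1 to compound 4 (within the scatter), not beyond the scatter. Compound 4 is therefore estimated to give about 8% in this assay, most likely between 0% and 25%.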

Compound 4, a percentage reported as inhibition, at one concentration (the size of the read-out at that concentration, not a potency): 3%
Compound 4: the middle estimate sits 5 percentage points above what was measured, and the stated range covers the measured number.
By their numbers in this assay, from the lowest: compounds 1 and 4 (each within the scatter of the next); then compounds 2 and 3 (each within the scatter of the next).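

In this assay, among the compounds shown here, the swap of 4-methoxyphenyl for pyridin-4-yl on a carbonyl carbon is the first one-place comparison in this set, and it gives no change at the digits printed from compound 1 to compound 4 (within the scatter). Compound 1 already reads 3%, close to the bottom of the scale, so this pair could reveal a rise far more readily than a fall, and no rise appears; a carbon-only ring carrying a methoxy group and a ring with one nitrogen atom therefore read alike at this position, at the single concentration tested. Nothing measured here gives a reason for this lack of change.

The compounds shown leave open whether a different group on this carbonyl carbon, such as a small methyl group, a longer alkyl chain, a saturated piperidine ring or a phenyl ring bearing a carboxylic acid, would lift the reading clear of the bottom of the scale. They also leave open whether the position can affect the reading at all when the rest of the molecule stays as it is in compound 1, since a single swap between two readings this low cannot settle that.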